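This account rests on a few compounds, and the source may have more. Where it says the series, first, only, none or still open, it means among the compounds named here.

Measured in an ADME assay on J774.1 cells (Mus musculus) for cytotoxicity, read by resazurin assay, with a stated time of 48 h (on this read-out lower numbers stand for stronger inhibition and higher numbers for weaker inhibition), all three values being limits:
- compound 1 `CCCCn1cc(C(=O)NCc2ccccc2)c(=O)c2cc(F)c(N(C)C)cc21`: > 100000 nM
- compound 2 `CCCCn1cc(C(=O)NCc2ccc(OC)c([N+](=O)[O-])c2)c(=O)c2cc(F)c(N3CCC(C(N)=O)CC3)cc21`: > 100000 nM
- compound 3 `CCCCn1cc(C(=O)O)c(=O)c2cc(F)c(N(C)C)cc21`: > 100000 nM

Compound 3 gives no number, only the limit > 100000 nM. It stands with the other two compounds at the limit of > 100000 nM in this assay, at which 3 of the 3 values shown sit. Compound 4 `CCCCn1cc(C(=O)O)c(=O)c2cc(F)c(N3CCCCC3)cc21` keeps the carboxylic acid of compound 3 and carries piperidin-1-yl in place of dimethylamino on an aromatic carbon. Going by the values given here, the only measured step is a step that the two limits leave unreadable from compound 1 to compound 3, a change of hydroxy in place of benzylamino on a carbonyl carbon. It lies elsewhere in the molecule, and its size cannot be read. Among the compounds with values here, no measured step therefore speaks to this exchange, and nothing in the data points to a step in either direction. In this assay, the expected change is none beyond the scatter, and a further limit is the likeliest report. The expected step is a number no higher from compound 3 to compound 4 (the limit leaves the size open). Compound 4 is estimated at 100000 nM, with an expected range from 40000 nM to 200000 nM.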

Compound 4, half-maximal inhibitory concentration: 93000 nM
Compound 4: the middle estimate sits 1.1-fold (0.03 log units) above what was measured; the range from low to high includes it.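

In this assay, the exchange of dimethylamino for piperidin-1-yl on this aromatic carbon, ortho to a fluoro group, gives an at least 1.0-fold lower number from compound 3 to compound 4 (0.03 log units; that floor lies within the scatter). Compound 4 is thus the only compound shown that reports a number rather than a limit, and with the carboxylic acid kept, this six-membered non-aromatic ring gives a value that cannot be set clearly apart from the limit of the other compounds: the limit of > 100000 nM in this assay, at which 3 of the 4 values shown sit.

On these data alone, how far compound 3 truly lies from compound 4 stays open, since its value is only a limit. Also open, as far as these compounds go, is whether a morpholin-4-yl or piperazin-1-yl group at this aromatic carbon, or piperidin-1-yl paired with a benzyl amide in place of the carboxylic acid, would give a clearly different number.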